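Chloro in place of trifluoromethyl: expecting compound 4

A few compounds are considered here, and "the series" means these few. Any claim that something is new, unique, unknown or untested is made for them only; others in the source may bear on it.

Measured in a functional assay (muscle tissue) with Cavia porcellus as the target; a lower number here means a stronger inhibitor, a higher number a weaker inhibitor:
- compound 1, `CC1=NC(C)=C([N+](=O)[O-])C(c2ccccn2)/C1=C(/O)OCCc1ccccc1`, gives 639 nM
- compound 2, `CC1=NC(C)=C([N+](=O)[O-])C(c2ncccc2C)/C1=C(/O)OCCc1ccccc1`, gives 5430 nM
- compound 3, `CC1=NC(C)=C([N+](=O)[O-])C(c2ncccc2C(F)(F)F)/C1=C(/O)OCCc1ccccc1`, gives > 59800 nM, which is a limit of the assay and not a number

Compound 3 therefore stands at the weak end of the three, and only a limit is known for it: the limit of > 59800 nM in this assay, at which 1 of the 3 values shown sits. Compound 4, `CC1=NC(C)=C([N+](=O)[O-])C(c2ncccc2Cl)/C1=C(/O)OCCc1ccccc1`, differs from compound 3 in one place: chloro in place of trifluoromethyl on an aromatic carbon.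

Going by the values given here, two measured steps bear on this change. Putting trifluoromethyl in place of hydrogen gave an at least 93-fold higher number from compound 1 to compound 3 (1.97 log units; beyond the scatter), and putting trifluoromethyl in place of methyl gave an at least 11-fold higher number from compound 2 to compound 3 (1.04 log units; beyond the scatter). The smaller swap of methyl for hydrogen gave only an 8.5-fold higher number from compound 1 to compound 2 (0.93 log units; beyond the scatter). Chloro enters as a single heavy atom, closer in count to methyl than to trifluoromethyl, so the number for compound 4 is expected to fall between the value of compound 2 and the limit of compound 3, a clearly lower number than compound 3 in this assay; the expected step is an at least 6.6-fold lower number from compound 3 to compound 4 (0.82 log units; beyond the scatter). The estimate for compound 4 in this assay is 9000 nM, with a range from 2500 nM to 40000 nM.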

Compound 4, half-maximal inhibitory concentration: 5170 nM
Beside the measured number, compound 4's estimate is 1.7-fold (0.24 log units) above it; the measured number falls inside the stated range.
By their numbers in this assay, from the lowest: compound 1; then compounds 4 and 2 (each within the scatter of the next). At a limit, above all of these: compound 3.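

In this assay, chloro and methyl at this position cannot be told apart: putting chloro in place of methyl gives a 1.1-fold lower number from compound 2 to compound 4 (0.02 log units; within the scatter). Chloro in place of hydrogen gives an 8.1-fold higher number from compound 1 to compound 4 (0.91 log units; beyond the scatter), so with compound 2 there are now two different groups at this position that both leave the number well above that of compound 1, which carries only hydrogen there. Trifluoromethyl, with its 4 heavy atoms against the 1 of chloro, stands apart from both, as shown by an at least 11-fold lower number from compound 3 to compound 4 (1.06 log units; beyond the scatter), but this step rests on a limit for compound 3 and not on a number: the limit of > 59800 nM in this assay, at which 1 of the 4 values shown sits.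

With only hydrogen, methyl, chloro and trifluoromethyl at this position, the compounds shown do not tell which feature of a group sets the number here. Going by these compounds alone, how a fluoro, a methoxy group or an amine at the same place would read in this assay stays open, as does whether the same order would hold with a longer chain in place of the one the four compounds share.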